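This account rests on a few compounds, and the source may have more. Where it says the series, first, only, none or still open, it means among the compounds named here.

Measured compounds:
- compound 1, `CC[C@@H]1C(=O)N(C)c2cnc(Nc3ccc(S(N)(=O)=O)cc3)nc2N1C1CCCC1`: 3390 nM
- compound 2, `CCC1C(=O)N(C)c2cnc(Nc3ccc(S(=O)(=O)NC)cc3)nc2N1c1ccn(C)n1`: 12600 nM
- compound 3, `CCC1C(=O)N(C)c2cnc(-n3ccc4cc(C(=O)NC5CCCC5)ccc43)nc2N1c1ccn(C)n1`: 39500 nM

In a functional assay on A549 cells (Homo sapiens) for antiproliferative activity, read by CCK-8 assay, with a stated time of 72 h (on this read-out higher numbers stand for weaker inhibition of growth and lower numbers for stronger inhibition of growth), compound 1 gives 3390 nM, the lowest of the three numbers; compound 2 sits a good way higher at 12600 nM, and compound 3 further still at 39500 nM, both gaps beyond the scatter. Compound 4, `CC[C@@H]1C(=O)N(C)c2cnc(Nc3ccc(S(=O)(=O)NC)cc3)nc2N1C1CCCC1`, has not yet been measured in this assay. It differs from compound 1 in one place: methyl in place of hydrogen on a sulfonamide nitrogen. Compound 2 also carries a methylsulfamoyl group, but it differs from compound 1 elsewhere as well, so its value alone does not isolate this change. The step from compound 1 to compound 4 is expected to be small, at most a modest weakening, a 1.3-fold higher number from compound 1 to compound 4 (0.12 log units; within the scatter). Compound 4 is estimated at 4500 nM, within 1800 nM to 11000 nM.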

Compound 4, concentration for 50% growth inhibition: 183 nM
For compound 4 the middle estimate is 25-fold (1.39 log units) above the measured one, and the stated range ends above it.
By their numbers in this assay, from the lowest: compound 4; then compound 1; then compound 2; then compound 3.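

In this assay, the sulfonamide nitrogen proves a sensitive position, since methyl in place of hydrogen there gives a 19-fold lower number from compound 1 to compound 4 (1.27 log units; beyond the scatter). Within the data shown here, the earlier compounds held no pair differing in one place, so this is the first isolated reading of the change from sulfamoyl to methylsulfamoyl. No measurement shown accounts for the size of this step.

Going by these compounds, whether ethyl or a longer chain on this nitrogen, or a second methyl on it, would hold or lose the step stays open. So does whether the same change acts alike on a core carrying another group in place of the cyclopentyl.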